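Bulky amide on the chlorophenyl piperazine: compound 4

The source may report more compounds than this note shows. Statements on the series, on what has been measured and on what is new or still open speak of the compounds shown alone.

The series shares a butyl-linked amide on an aryl piperazine. Among the measured compounds shown here, in an assay on HEK293 cells for binding affinity to D(4) dopamine receptor (Homo sapiens), read by radioligand binding (a lower number here means a stronger inhibitor, a higher number a weaker inhibitor), compound 1 `COc1ccccc1N1CCN(CCCCNC(=O)C(C)(C)C)CC1` gives 12.6 nM and compound 2 `COc1cc(Cl)ccc1N1CCN(CCCCNC(=O)C(C)(C)C)CC1` gives 15.9 nM; the single step of a 1.3-fold higher number from compound 1 to compound 2 (0.10 log units; within the scatter) shows that a chloro on the aromatic ring leaves the number essentially where it was. Compound 3 `CC(=O)NCCCCN1CCN(c2ccc(Cl)cc2)CC1`, with an acetyl amide and no methoxy group, gives 1260 nM in this assay, the highest of the three numbers; set against compound 1 and compound 2 its value lies far above both, and it is the weakest binder shown.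

Compound 4 `CCCC(C)(C)C(=O)NCCCCN1CCN(c2ccc(Cl)cc2)CC1` keeps the core of compound 3 and changes only the amide: 1,1-dimethylbutyl in place of methyl on a carbonyl carbon. For the measured compounds named here, no measured pair covers this change directly. What the data offer is that both compound 1 and compound 2, which carry a larger branched group on the carbonyl carbon, sit well below compound 3, while the chloro step in this assay is flat; this leaves the amide as the part of the difference that is not accounted for by the aromatic substituent. On that basis a clear drop in this assay is expected for compound 4, estimated as a 13-fold lower number from compound 3 to compound 4 (1.10 log units; beyond the scatter), giving a value of 100 nM with a range of 25 nM to 400 nM.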

Compound 4, inhibition constant: 12.6 nM
The estimate for compound 4 lay 7.9-fold (0.90 log units) above the measured number; measured number below the stated range.
By their numbers in this assay, from the lowest: compounds 1, 4 and 2 (each within the scatter of the next); then compound 3.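

In this assay, among the compounds shown here, the change of methyl to 1,1-dimethylbutyl on a carbonyl carbon is now isolated on an otherwise unchanged core, and a 100-fold lower number from compound 3 to compound 4 (2.00 log units; beyond the scatter) shows that this position alone can move the number by a large step, whereas the earlier compounds tied the amide to other differences and the only single-place step, a 1.3-fold higher number from compound 1 to compound 2 (0.10 log units; within the scatter), stayed within the scatter. Compound 4 also reaches 12.6 nM with no methoxy group on the aromatic ring, so a number this low in the series does not depend on that group. Nothing at hand bears on why this amide change moves the number.

With only methyl and 1,1-dimethylbutyl on this carbonyl carbon in the core of compound 3, the two ends of the step are known but the path between them is not, and a straight propyl chain or a cyclohexyl ring in the same place would show whether branching or a ring changes the outcome. Also open, going by these compounds, is whether a terminal amine or carboxylic acid on the 1,1-dimethylbutyl chain would keep the number of compound 4.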